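Compound 4 Expected: 4-Nitrophenyl in Place of 2-Phenylethenyl

The source may hold more compounds than are shown below. What is called first, only, known or untested is meant among the compounds shown, and "the series" means these compounds.

Of the compounds shown here, three built on a shared core have been tested in a functional assay on the whole organism (B cells) with Mus musculus as the target; on this read-out higher numbers stand for larger maximal responses and lower numbers for smaller maximal responses. Compound 1 `Nc1nc(O)c2c(n1)n(C1OC(CO)[C@@H](O)[C@H]1O)c(=O)n2C/C=C/c1ccccc1` gives 73%, the lowest of the three numbers. Compound 3 `C=CCn1c(=O)n(C2C[C@H](O)C(CO)O2)c2nc(N)nc(O)c21` gives 99%, a value beyond the scatter above compound 1, and compound 2 `C=CCn1c(=O)n(CCCCCCCC)c2nc(N)nc(O)c21` gives 130%, further above still. No two of these compounds differ in only one place, and no single measured step can be read off from them.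

Compound 4 `Nc1nc(O)c2c(n1)n(C1OC(CO)[C@@H](O)[C@H]1O)c(=O)n2Cc1ccc([N+](=O)[O-])cc1` has not yet been measured. It differs from compound 1 in one place: 4-nitrophenyl in place of 2-phenylethenyl on a saturated chain carbon bound to an aromatic nitrogen. The 2-phenylethenyl group leaves and the 4-nitrophenyl group enters on a saturated chain carbon bound to an aromatic nitrogen. Among the measured compounds shown here, no measured pair shows what this exchange does to the maximal response, and the size of the step remains unknown. The step expected here, a number 2 percentage points higher from compound 1 to compound 4 (within the scatter), is estimated to stay within the scatter, with no clear direction. In this assay compound 4 is therefore estimated at 75%, in a range from 45% to 110%.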

Compound 4, largest response reached (reported as maximal response), in percent of the reference or control that the assay uses: 147%
For compound 4 the middle estimate is 72 percentage points below the measured one; measured number above the stated range.
By their numbers in this assay, from the lowest: compound 1; then compound 3; then compound 2; then compound 4.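

In this assay, the change from 2-phenylethenyl to 4-nitrophenyl on a saturated chain carbon bound to an aromatic nitrogen gives a number 74 percentage points higher from compound 1 to compound 4 (beyond the scatter), so this position on the shared core can respond strongly to the group placed there. Both groups carry one six-membered aromatic ring of carbon only, which means that keeping such a ring at this place does not fix the maximal response. The entering group also brings two oxygens and a nitrogen, and it has hydrogen-bond acceptors where the leaving group has none, but no measurement here explains the step.

The compounds shown leave open whether the step follows the nitro group or the change from 3-phenylprop-2-en-1-yl to a benzyl frame. A plain benzyl group, or an amine in place of the nitro group, would help separate these two parts of the change.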